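This account rests on a few compounds, and the source may have more. Where it says the series, first, only, none or still open, it means among the compounds named here.

Three compounds built on one shared core were tested in a functional assay on A549 cells (Homo sapiens) for cytotoxicity, read by MTT assay, with a stated time of 72 h; on this read-out lower numbers stand for stronger inhibition and higher numbers for weaker inhibition. Compound 3 `O=C1c2c[n+]([O-])c3ccccc3c2C(=O)c2[nH]c3ccccc3c21` gives 320 nM. Compound 1 `CN1CCN(CCCCCCn2c3c(c4ccccc42)C(=O)c2c[n+]([O-])c4ccccc4c2C3=O)CC1` gives 330 nM, and compound 2 `O=C1c2c[n+]([O-])c3ccccc3c2C(=O)c2c1c1ccccc1n2Cc1cn([C@H]2C[C@H](O)[C@@H](CO)O2)nn1` gives 350 nM. Compound 3 shows the lowest of the three numbers, but both gaps lie within the usual scatter, so the three cannot be told apart on these data. Compound 4 `O=C1c2c[n+]([O-])c3ccccc3c2C(=O)c2c1c1ccccc1n2Cc1cn(CC(O)CO)nn1` has not yet been measured. It differs from compound 3 in one place: (1-(2,3-dihydroxypropyl)-1H-1,2,3-triazol-4-yl)methyl in place of hydrogen on an aromatic nitrogen. Compounds 1 and 2 each carry an added group, yet compound 1 gives 330 nM and compound 2 gives 350 nM, both close to compound 3. On that basis the expected step is a 1.1-fold higher number from compound 3 to compound 4 (0.03 log units; within the scatter), staying within the scatter. Compound 4 is therefore estimated at 340 nM, between 160 nM and 750 nM.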

Compound 4, half-maximal inhibitory concentration: 880 nM
The estimate for compound 4 lay 2.6-fold (0.41 log units) below the measured number; measured number outside the range, above it.
By their numbers in this assay, from the lowest: compounds 3, 1 and 2 (each within the scatter of the next); then compound 4.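

Placing (1-(2,3-dihydroxypropyl)-1H-1,2,3-triazol-4-yl)methyl on this aromatic nitrogen gives a 2.8-fold higher number from compound 3 to compound 4 (0.44 log units; beyond the scatter) here, so a large added group at this position can shift the number beyond the scatter. The end of the group also counts: 2,3-dihydroxypropyl in place of 4-hydroxy-5-(hydroxymethyl)oxolan-2-yl gives a 2.5-fold higher number from compound 2 to compound 4 (0.40 log units; beyond the scatter) and 1-(2,3-dihydroxypropyl)-1H-1,2,3-triazol-4-yl in place of 5-(4-methylpiperazin-1-yl)pentyl gives a 2.7-fold higher number from compound 1 to compound 4 (0.43 log units; beyond the scatter) as well. No supporting measurement explains these shifts. Still open, on these data alone, is whether a smaller end on the same ring, such as a methyl or a 2-aminoethyl group, would keep the number close to that of compound 3.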